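The source may hold more compounds than are shown below. What is called first, only, known or untested is meant among the compounds shown, and "the series" means these compounds.

Measured so far:
Compound 1 `O/N=C(/Nc1ccc(F)c(Cl)c1)c1ccc2occc2c1` gives 5200 nM in an assay on isolated protein for inhibition of Indoleamine 2,3-dioxygenase 1 (Homo sapiens), read by spectrophotometry; a higher number here means a weaker inhibitor, a lower number a stronger inhibitor.
Compound 2 `O/N=C(/NCc1ccccc1)c1ccc2occc2c1` gives > 30000 nM in this assay, which is a limit of the assay and not a number.

Compound 2 thus stands at the edge of what this assay can report: the limit of > 30000 nM in this assay, at which 1 of the 2 values shown sits. Among the measured compounds shown here, compound 1 and compound 2 differ in more than one place, so no single step links them, and their two values show only that compound 1 gives a number where compound 2 does not.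

Compound 3 `O/N=C(/NCc1cccs1)c1ccc2occc2c1` is not yet measured. It differs from compound 2 in one place: thiophen-2-yl in place of phenyl on a saturated chain carbon bound to an amine nitrogen. One aromatic ring is swapped for another on the same saturated chain carbon bound to the amine nitrogen, and a swap of this kind is expected to move this assay by no step beyond the usual scatter, in neither direction. The step that this estimate means is a number no higher from compound 2 to compound 3 (the limit leaves the size open), expected to stay within the scatter. Compound 3 is therefore estimated at 30000 nM, within a range from 10000 nM to 100000 nM, with a real chance that the assay once more reports only a limit.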

Compound 3, half-maximal inhibitory concentration: > 30000 nM
Compound 3 ended at the assay's limit (the forecaster's own chance of this, stated with the estimate: 60%); the middle value sits exactly at the limit.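

Compound 2 and compound 3 both end at a limit of the assay and not at a number, so no step can be read between them: the limit of > 30000 nM in this assay, at which 2 of the 3 values shown sit.

The compounds shown leave open whether thiophen-2-yl in place of phenyl on this saturated chain carbon shifts the real strength of inhibition in this assay at all, and by how much.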